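The source may hold more compounds than are shown below. What is called first, only, known or untested is meant among the compounds shown, and "the series" means these compounds.

Two esters of the same core have been examined in a functional assay on HCT-15 cells (Homo sapiens) for antiproliferative activity, read by sulforhodamine B assay, with a stated time of 48 h, tested at 50 uM; on this read-out lower numbers stand for less inhibition and higher numbers for more inhibition at the one concentration tested (going by the name of the read-out). Compound 1, `COc1cccc(C(=O)Oc2cc3c(cc2C)[C@@H](C(C)C)CC=C3C)c1`, is recorded in this assay as "not active" (no number reported), with no number given. Going by the values given here, compound 2, `CC1=CC[C@H](C(C)C)c2cc(C)c(OC(=O)c3ccc(C(F)(F)F)cc3)cc21`, is the one compound for which a number stands: in this assay compound 2 gives 6.4%, a small inhibition at the single concentration tested. Compound 3, `CC1=CC[C@H](C(C)C)c2cc(C)c(OC(=O)c3ccc(Cl)cc3)cc21`, has not yet been measured. Its difference from compound 2 is chloro in place of trifluoromethyl on an aromatic carbon. Among the compounds with values here, no step between two measured compounds is available to calibrate such a change, so the expectation rests on compound 2 alone. Because compound 2 gives 6.4%, compound 3 is expected to show a step of a number 0.4 percentage points lower from compound 2 to compound 3 (within the scatter), that is, no movement beyond the usual scatter in either direction. In this assay compound 3 is accordingly estimated at 6%, within a range from 0% to 16%.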

Compound 3, a percentage reported as inhibition, at one concentration (the size of the read-out at that concentration, not a potency): 47.4%
Compound 3: the middle estimate sits 41.4 percentage points below what was measured, and the stated range ends below it.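

In this assay, chloro in place of trifluoromethyl gives a number 41 percentage points higher from compound 2 to compound 3 (beyond the scatter), a large step that one value could not have shown. It establishes that this aromatic carbon, para to a large group, is sensitive to the group it carries: exchanging four heavy atoms for one changes the inhibition at the single concentration tested well beyond the usual variation between repeats. No measurement available here explains why these two groups differ so strongly.

Going by these compounds, it remains open whether the higher inhibition is particular to chloro or would also appear with another group at this place, such as bromo, fluoro, nitrile or an amine. On these data alone, compound 3 is also described at only one concentration, so whether its stronger effect and the step would hold at other concentrations remains unknown.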